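The source may report more compounds than this note shows. Statements on the series, on what has been measured and on what is new or still open speak of the compounds shown alone.

Measured compounds:
compound 1 `COc1cc(-n2cccc2C(=O)N2CCCCC2)ccc1Nc1ncc(Cl)c(Nc2ccccc2NS(C)(=O)=O)n1`: 630 nM
compound 2 `COc1cc(-n2cccc2C(=O)N2CCC(C)CC2)ccc1Nc1ncc(Cl)c(Nc2ccccc2NS(C)(=O)=O)n1`: 1050 nM

In a functional assay on NCI-H2228 cells (Homo sapiens) for antiproliferative activity, read by MTT assay, with a stated time of 72 h (on this read-out higher numbers stand for weaker inhibition and lower numbers for stronger inhibition), compound 2 gives the higher of the two numbers shown, yet the step of a 1.7-fold higher number from compound 1 to compound 2 (0.22 log units; within the scatter) does not separate the two compounds. Compound 2 therefore stands level with compound 1 on present evidence, and no order between them can be claimed.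

Compound 3 `CCN(CC)C(=O)c1cccn1-c1ccc(Nc2ncc(Cl)c(Nc3ccccc3NS(C)(=O)=O)n2)c(OC)c1` differs from compound 2 by diethylamino in place of 4-methylpiperidin-1-yl on a carbonyl carbon. Going by the values given here, the one measured step, a 1.7-fold higher number from compound 1 to compound 2 (0.22 log units; within the scatter), also changes the group on the same carbonyl carbon, but it adds a methyl to a saturated ring carbon rather than exchanging the ring for an open-chain group, so it bears on the new step only loosely. It shows that this part of the shared core tolerated a small change without a shift beyond the scatter. Among the compounds with values here, no measured pair covers the exchange of a ring for an open chain on this carbonyl, so the expected step of a 1.2-fold lower number from compound 2 to compound 3 (0.09 log units; within the scatter) is taken as one that stays within the scatter, with the range widened for that uncertainty. Compound 3 is thus estimated at 850 nM, between 300 nM and 2500 nM.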

Compound 3, half-maximal inhibitory concentration: 870 nM
Compound 3: middle estimate off by 1.0-fold (0.01 log units), on the low side; low and high end bracket the measured number.
By their numbers in this assay, from the lowest: compounds 1, 3 and 2 (each within the scatter of the next).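

In this assay, exchanging the ring on the carbonyl carbon for diethylamino gives a 1.2-fold lower number from compound 2 to compound 3 (0.08 log units; within the scatter), and the same exchange made from piperidin-1-yl gives a 1.4-fold higher number from compound 1 to compound 3 (0.14 log units; within the scatter). The earlier pair changed only a methyl on a saturated ring carbon, whereas these steps remove the ring altogether, and diethylamino, with no ring, stands level with both piperidin-1-yl and 4-methylpiperidin-1-yl, so among these three compounds the ring is not needed for a number in this range. No supporting data are available to explain this level standing.

Still open, as far as these compounds go, is whether this tolerance extends to groups on the carbonyl carbon that carry a further hetero atom, such as morpholine or piperazine, or to an unsubstituted amide or a carboxylic acid in place of the whole amide. Also open, from the compounds shown here alone, is whether a longer chain than ethyl on the amide nitrogen, such as dipropylamino or dibutylamino, or a smaller group such as dimethylamino, would stay within the scatter of these three compounds.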